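Chloro to nitro on a shared piperazine-acetamide series

The source may hold more compounds than are shown below. What is called first, only, known or untested is meant among the compounds shown, and "the series" means these compounds.

Compound 1 `COc1ccc(-c2nnc(N3CCN(C(=O)CN4CCN(c5ccc(Cl)cc5)CC4)CC3)nc2-c2ccc(OC)cc2)cc1`: 607000 nM
Compound 2 `COc1ccc(-c2nnc(N3CCN(C(=O)CN4CCN(c5ccc([N+](=O)[O-])cc5)CC4)CC3)nc2-c2ccc(OC)cc2)cc1`: > 801000 nM
Compound 3 `O=C(CN1CCN(c2ccc(Cl)cc2)CC1)N1CCN(c2nnc(-c3ccc(Cl)cc3)c(-c3ccc(Cl)cc3)n2)CC1`: > 803000 nM

In a functional assay on MCF7 cells (Homo sapiens) for cytotoxicity, read by MTT assay, with a stated time of 24 h (a higher number here means a weaker inhibitor, a lower number a stronger inhibitor), compound 1 gives 607000 nM. Compound 2 in this assay reaches only a limit of the assay, > 801000 nM. Compound 3 likewise reports only a limit in this assay, > 803000 nM.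

The change from compound 1 to compound 2 is nitro in place of chloro on an aromatic carbon and it gives an at least 1.3-fold higher number from compound 1 to compound 2 (0.12 log units; that floor lies within the scatter), a step whose floor is set by the limit of > 801000 nM in this assay, at which 1 of the 3 values shown sits. The same change, (nitro in place of chloro on an aromatic carbon), leads from compound 3 to compound 4 `O=C(CN1CCN(c2ccc([N+](=O)[O-])cc2)CC1)N1CCN(c2nnc(-c3ccc(Cl)cc3)c(-c3ccc(Cl)cc3)n2)CC1`, which has not yet been measured in this assay. The difference between the core of compound 1 and the core of compound 3 is not broken down here.

Since the earlier step stayed within the scatter and compound 3 already sits at a limit, compound 4 is expected to show a step that the limit leaves unreadable from compound 3 to compound 4 in this assay. Compound 4 is therefore estimated at 1000000 nM, with an expected range from 600000 nM to 2500000 nM, most likely again reported only as a limit.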

Compound 4, half-maximal inhibitory concentration: > 789000 nM
Compound 4 was reported as a limit; the forecaster's own chance of this, stated with the estimate: 85%; the middle value does not contradict the limit.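

In this assay compound 4 gives only a limit, > 789000 nM. Going by these compounds alone, compound 3 also gives only a limit, > 803000 nM, so no step from compound 3 to compound 4 can be read. The compounds shown leave open how strong compound 3 and compound 4 really are, and whether nitro in place of chloro makes any difference on this core.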